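This account rests on a few compounds, and the source may have more. Where it says the series, first, only, none or still open, it means among the compounds named here.

Compound 2 `COc1ccc(/C=C/c2cc(OC)cc(OC)c2/C=C/C(=O)c2ccc(C)c(C)c2)cc1` carries the shared core with a 3,4-dimethylphenyl group on the carbonyl carbon. Among the compounds with values here, in a functional assay on A549 cells (Homo sapiens) for antiproliferative activity, read by MTT assay, with a stated time of 48 h (on this read-out higher numbers stand for weaker inhibition and lower numbers for stronger inhibition), compound 2 gives 0.1 ug/mL, the lowest number of the two compounds measured so far. Within the data shown here, its only neighbour is compound 1 `COc1ccc(/C=C/c2cc(OC)cc(OC)c2/C=C/C(=O)c2ccc(C(F)(F)F)cc2)cc1`, which in this assay gives 7.8 ug/mL; the single structural difference between the two sits on that carbonyl carbon and amounts to a 78-fold lower number from compound 1 to compound 2 (1.89 log units; beyond the scatter).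

Compound 3 `COc1ccc(/C=C/c2cc(OC)cc(OC)c2/C=C/C(=O)c2cccc(OC)c2)cc1` has not yet been measured. It differs from compound 2 in one place: 3-methoxyphenyl in place of 3,4-dimethylphenyl on a carbonyl carbon. Among the measured compounds shown here, no measured step swaps these two particular groups, so there is no direct guide. For the measured compounds named here, the one step that does exist, from compound 1 to compound 2, shows that changing the aryl group on the carbonyl carbon can move the number a long way. The expected outcome is a step of an 8.0-fold higher number from compound 2 to compound 3 (0.90 log units; beyond the scatter), with wide uncertainty. Compound 3 is therefore estimated at 0.8 ug/mL in this assay, with a range from 0.1 ug/mL to 6 ug/mL.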

Compound 3, half-maximal inhibitory concentration: 6.1 ug/mL
Beside the measured number, compound 3's estimate is 7.6-fold (0.88 log units) below it; the whole stated range lies below it.
By their numbers in this assay, from the lowest: compound 2; then compounds 3 and 1 (each within the scatter of the next).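

In this assay, putting 3-methoxyphenyl in place of 3,4-dimethylphenyl on the carbonyl carbon gives a 61-fold higher number from compound 2 to compound 3 (1.79 log units; beyond the scatter) and so shows that the low number of compound 2 does not carry over to this second aryl group. The step between the two other aryl groups reads a 1.3-fold lower number from compound 1 to compound 3 (0.11 log units; within the scatter) and leaves 3-methoxyphenyl and 4-(trifluoromethyl)phenyl indistinguishable here, although the two groups differ in what they carry on the ring. Among these three compounds, only the 3,4-dimethylphenyl group stands apart, with both of its steps beyond the scatter, and no supporting data are available to explain this gap.

The compounds shown leave open whether the low number needs both methyl groups or whether a single one, as in 3-methylphenyl or 4-methylphenyl, would be enough. On these data alone, how a plain phenyl ring, or an aryl ring bearing an amine or a carboxylic acid, would read on the same carbonyl carbon also remains unknown.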